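The compounds below may be only part of what the source reports. "The series", "measured", "known", "first", "only" and "open" are said of these compounds alone.

Working notes on the shared core, two members measured so far in a toxicity assay on MDCK cells (Canis lupus familiaris) for cytotoxicity, read by crystal violet staining, with a stated time of 48 h; a higher number here means that more compound is tolerated, a lower number that less compound is tolerated. Compound 1 `CCc1ccc2[nH]c(=O)c(CN(Cc3ccc(F)cc3)Cc3cccc4ccccc34)cc2c1` was recorded in this assay only as a limit, > 5000 nM. Compound 2 `Cc1ccc2[nH]c(=O)c(CN(Cc3ccc(OC(C)C)cc3)Cc3ccc(C(C)(C)C)cc3)cc2c1` likewise returns in this assay only a limit, > 5000 nM. Within the data shown here, both readings sit at the same limit, (the limit of > 5000 nM in this assay, at which 2 of the 2 values shown sit), so no step between measured compounds can be stated, and where compound 2 stands against compound 1 cannot be ordered: the two limits show only that neither compound reached the cytotoxic end point within the tested range.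

The next member, compound 3 `Cc1ccc2[nH]c(=O)c(CN(Cc3ccc(C(C)(C)C)cc3)[C@@H](C)c3ccc(F)cc3)cc2c1`, differs from compound 2 in one place: 1-(4-fluorophenyl)ethyl in place of 4-isopropoxybenzyl on an amine nitrogen. Among the measured compounds shown here, no measured step speaks to whether 1-(4-fluorophenyl)ethyl in place of 4-isopropoxybenzyl on the amine nitrogen alters tolerance on these cells. Given that both measured members sit at the limit (the limit of > 5000 nM in this assay, at which 2 of the 2 values shown sit), the step from compound 2 to compound 3 in this assay is expected to be none beyond the scatter, a step that the limit leaves unreadable from compound 2 to compound 3. Compound 3 is accordingly estimated in this assay at about 8000 nM, with a range of 4000 nM to 20000 nM, most likely reported once more only as a limit.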

Compound 3, half-maximal cytotoxic concentration: > 5000 nM
Compound 3: no number, only a limit; the forecaster's own chance of this, stated with the estimate: 75%; the middle value lies beyond the limit too.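

In this assay, among these compounds, compound 3 is recorded only as a limit (> 5000 nM), so no step from compound 2 to compound 3 can be read: (the limit of > 5000 nM in this assay, at which 3 of the 3 values shown sit). The compounds shown leave open whether any member reaches the cytotoxic end point on these cells, and whether 1-(4-fluorophenyl)ethyl in place of 4-isopropoxybenzyl alters tolerance at all.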